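Replacing cyano with pentafluoroethyl in compound 2

The source may report more compounds than this note shows. Statements on the series, on what has been measured and on what is new or still open speak of the compounds shown alone.

In a functional assay (aorta) with Rattus norvegicus as the target (on this read-out higher numbers stand for an effect only at larger amounts of compound and lower numbers for an effect already at smaller amounts), compound 1 `O=C1CCCN1C1=CC(CF)(CF)Oc2ccc(C(F)(F)C(F)(F)F)cc21` gives 1.51 nM and compound 2 `N#Cc1ccc2c(c1)C(c1cccc[n+]1[O-])=CC(CF)(CF)O2` gives 16.6 nM as the higher of the two numbers, a gap beyond the scatter. Compound 3 `[O-][n+]1ccccc1C1=CC(CF)(CF)Oc2ccc(C(F)(F)C(F)(F)F)cc21` is compound 2 with 1,1,2,2,2-pentafluoroethyl in place of cyano on an aromatic carbon and remains unmeasured. Compound 1 also carries 1,1,2,2,2-pentafluoroethyl, though with a different second group, and stands at 1.51 nM in that read-out, so a lower number is expected. The expected change is a 5.5-fold lower number from compound 2 to compound 3 (0.74 log units; beyond the scatter) in this assay and would lie beyond the scatter. Compound 3 is estimated at 3 nM with an expected range of 0.8 nM to 12 nM in that read-out.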

Compound 3, half-maximal effective concentration: 1.7 nM
Beside the measured number, compound 3's estimate is 1.8-fold (0.25 log units) above it; measured number inside the range.
By their numbers in this assay, from the lowest: compounds 1 and 3 (each within the scatter of the next); then compound 2.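

On the aromatic carbon, with the group on the double-bonded ring carbon held fixed, 1,1,2,2,2-pentafluoroethyl in place of cyano gives a 9.8-fold lower number from compound 2 to compound 3 (0.99 log units; beyond the scatter) in this assay and so shows that this exchange alone moves the read-out. With 1,1,2,2,2-pentafluoroethyl held fixed, exchanging the five-membered non-aromatic ring group for the six-membered aromatic ring group on the double-bonded ring carbon gives a 1.1-fold higher number from compound 1 to compound 3 (0.05 log units; within the scatter) and does not separate the two groups. No measurement offers an explanation for either step. From the compounds shown here alone, it remains open how a trifluoromethyl group or a chlorine atom on the aromatic carbon would compare, and how an amine would fare on the double-bonded ring carbon.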